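Dropping One Fluoro Group From a Difluorophenyl Amide

This account rests on a few compounds, and the source may have more. Where it says the series, first, only, none or still open, it means among the compounds named here.

Measured so far in an assay on membranes from Cerebral cortex for displacement of a labelled ligand from Neuronal acetylcholine receptor; alpha4/beta2 (Rattus norvegicus); on this read-out lower numbers stand for stronger inhibition and higher numbers for weaker inhibition:
- Compound 1, `COc1cc(NC(=O)c2cncc(N3CC4CC(C3)N4)c2)cc(OC)c1`: 0.985 nM
- Compound 2, `O=C(Nc1ccc(F)cc1F)c1cncc(N2CC3CC(C2)N3)c1`: 0.051 nM
- Compound 3, `O=C(Nc1ccc(Cl)cc1)c1cncc(N2CC3CC(C2)N3)c1`: 0.404 nM

Among these three, compound 2 stands at the lowest number, and so at the strongest inhibition. Its nearest neighbour is compound 3, reached by a 7.9-fold higher number from compound 2 to compound 3 (0.90 log units; beyond the scatter); compound 1 lies furthest away, its value being well beyond the scatter from that of compound 2.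

Compound 4, `O=C(Nc1ccccc1F)c1cncc(N2CC3CC(C2)N3)c1`, is not yet measured. It differs from compound 2 in one place: hydrogen in place of fluoro on an aromatic carbon.

Going by the values given here, only one measured step touches this part of the molecule, a 7.9-fold higher number from compound 2 to compound 3 (0.90 log units; beyond the scatter), and it exchanges both fluoro groups together for a single chloro, so it is not a clean guide. It does show that changes on this ring can shift the number by a modest but clearly visible amount. Removing just one fluoro is expected to cost some potency, so a modest step toward higher numbers, a 2.9-fold higher number from compound 2 to compound 4 (0.47 log units; beyond the scatter), is anticipated. Compound 4 is therefore estimated at 0.15 nM, within a range of 0.05 nM to 0.5 nM.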

Compound 4, inhibition constant: 0.315 nM
For compound 4 the middle estimate is 2.1-fold (0.32 log units) below the measured one; low and high end bracket the measured number.
By their numbers in this assay, from the lowest: compound 2; then compounds 4 and 3 (each within the scatter of the next); then compound 1.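

Taken alone, the fluoro group that leaves compound 2 has a clear effect in this assay: putting hydrogen in its place on the aromatic carbon gives a step beyond the scatter (a 6.2-fold higher number from compound 2 to compound 4 (0.79 log units; beyond the scatter)). The earlier step could not show this, since both fluoro groups left together and a chloro entered. The 2-fluorophenyl and 4-chlorophenyl amides lie within the scatter of each other (a 1.3-fold lower number from compound 3 to compound 4 (0.11 log units; within the scatter)), so these two different rings cannot be told apart on this read-out. Nothing measured here explains the effect of the fluoro group.

Whether the other fluoro group matters as much on its own remains open, since no 4-fluorophenyl amide is among these compounds. Also open, on these data alone, is how a hydroxyl, an amine or a nitrile would compare with fluoro at this place.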